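Swapping the amide substituent on a bromo core

The source may hold more compounds than are shown below. What is called first, only, known or untested is meant among the compounds shown, and "the series" means these compounds.

Measured compounds:
Compound 1 `N=c1oc2ccc(Br)cc2cc1C(=O)NC1CCCCC1`: 10%
Compound 2 `CCC(CO)NC(=O)c1cc2cccc(OC)c2oc1=N`: 39%
Compound 3 `COc1cccc2cc(C(=O)NC3CCCCC3)c(=N)oc12`: > 70%

Three compounds were measured in an assay on HEK293 cells for displacement of a labelled ligand from adenosine receptor A2b (Homo sapiens), read by scintillation counting, with a stated time of 30 min, tested at 10 uM; on this read-out higher numbers stand for more inhibition at the one concentration tested (going by the name of the read-out) and lower numbers for less inhibition. Compound 3 `COc1cccc2cc(C(=O)NC3CCCCC3)c(=N)oc12` reaches the limit of this assay; its value > 70% is a limit and not a number (the limit of > 70% in this assay, at which 1 of the 3 values shown sits). Compound 2 `CCC(CO)NC(=O)c1cc2cccc(OC)c2oc1=N` gives 39% in this assay, and compound 1 `N=c1oc2ccc(Br)cc2cc1C(=O)NC1CCCCC1` gives 10%, the lowest of the two numbers shown.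

Compound 2 arises from compound 3 by one change, (1-(hydroxymethyl)propyl in place of cyclohexyl on an amide-type nitrogen), and this brought a number at least 31 percentage points lower from compound 3 to compound 2 (beyond the scatter), a large step beyond the scatter. Compound 1 and compound 3 carry different cores; the difference between the two cores is not broken down here.

Compound 4 `CCC(CO)NC(=O)c1cc2cc(Br)ccc2oc1=N` has not yet been measured in this assay. It arises from compound 1 by 1-(hydroxymethyl)propyl in place of cyclohexyl on an amide-type nitrogen, the same change as that from compound 3 to compound 2, made in the same place. Given that compound 1 already sits at 10%, there is little room for a downward step of similar size. The step is expected to be a number 5 percentage points lower from compound 1 to compound 4 (within the scatter), smaller in size than the earlier one only because compound 1 gives 10% and the scale cannot fall further. Compound 4 is therefore estimated to give 5% in this assay, with a range expected from 0% to 20%.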

Compound 4, a percentage reported as inhibition, at one concentration (the size of the read-out at that concentration, not a potency): 4%
Compound 4: middle estimate off by 1 percentage points, on the high side; low and high end bracket the measured number.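

In this assay, putting 1-(hydroxymethyl)propyl in place of cyclohexyl on an amide-type nitrogen gives a number 6 percentage points lower from compound 1 to compound 4 (within the scatter), so no real change can be claimed for this pair, and the result gives no reason why it differs from the earlier pair. The change therefore does not carry over at a single size from one core to the other, and its effect in this small series depends on which of the two cores it is made on: the same change on two cores in this assay, a number at least 31 percentage points lower (beyond the scatter) from compound 3 to compound 2 and a number 6 percentage points lower (within the scatter) from compound 1 to compound 4, at least 25 percentage points apart, beyond the scatter of two such steps

Going by these compounds, compound 3 stands at > 70%, which is a limit and not a number, so the full size of the step on its core stays unknown.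

The compounds shown cover only two cores and one replacement for cyclohexyl, so they cannot say whether the gap between the steps would hold for other amide substituents, such as a longer alkyl chain, a benzyl group or a chain ending in an amine or a carboxylic acid. They also leave open how the same change would behave on a core carrying chlorine or a methyl group in place of the bromine of compound 1.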